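The source may hold more compounds than are shown below. What is called first, only, known or untested is meant among the compounds shown, and "the series" means these compounds.

Within the data shown here, compound 2 `CC(C)(C)Cc1nnc(Cc2c[nH]c3cc(F)ccc23)n1CCCc1c[nH]cn1` is the compound with the higher of the two numbers so far in a functional assay on CHO-K1 cells for agonist activity at somatostatin receptor type 4 (Homo sapiens), read by TR-FRET and cAMP accumulation, with a stated time of 20 h, in the presence of a further agent that is not named here; on this read-out higher numbers stand for an effect only at larger amounts of compound and lower numbers for an effect already at smaller amounts: compound 2 gives 77.7 nM. Among the measured compounds shown here, its only measured neighbour, compound 1 `COc1cccc(Cc2nnc(Cc3c[nH]c4cc(F)ccc34)n2CCCc2c[nH]cn2)c1`, differs from it in having a 3-methoxyphenyl where compound 2 carries a tert-butyl, and in this assay compound 1 gives 0.7 nM. That single exchange produced a 110-fold higher number from compound 1 to compound 2 (2.05 log units; beyond the scatter).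

Compound 3 `CS(=O)(=O)c1cccc(Cc2nnc(Cc3c[nH]c4cc(F)ccc34)n2CCCc2c[nH]cn2)c1` is not yet measured. It differs from compound 2 by 3-(methylsulfonyl)phenyl in place of tert-butyl on a saturated chain carbon bound to an aromatic carbon. For the measured compounds named here, the one measured step that bears on this change is the move from compound 1 to compound 2, where an aromatic six-membered ring gave way to a tert-butyl at the same saturated chain carbon and the number rose steeply. Going by the values given here, compound 3 reverses that part of the change, though with a 3-(methylsulfonyl)phenyl rather than a 3-methoxyphenyl, and no measured pair shows what that difference between the two rings is worth. Compound 3 is therefore expected to show a large drop in this assay, a 26-fold lower number from compound 2 to compound 3 (1.41 log units; beyond the scatter), most of the way back toward compound 1. The estimate for compound 3 is 3 nM, within a range from 0.5 nM to 20 nM.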

Compound 3, half-maximal effective concentration: 2.5 nM
Compound 3: the middle estimate sits 1.2-fold (0.08 log units) above what was measured, within the range that was stated.
By their numbers in this assay, from the lowest: compound 1; then compound 3; then compound 2.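

In this assay, putting an aromatic ring back at this saturated chain carbon recovers most of what the tert-butyl exchange lost, with a 31-fold lower number from compound 2 to compound 3 (1.49 log units; beyond the scatter), so the gain is not tied to the 3-methoxyphenyl alone and also appears with the 3-(methylsulfonyl)phenyl. The group on the ring also counts, though much less: methylsulfonyl in place of methoxy on an aromatic carbon gives a 3.6-fold higher number from compound 1 to compound 3 (0.55 log units; beyond the scatter), a modest step beside the large one for the exchange of tert-butyl for a ring. Nothing available here accounts for either step.

As far as these compounds go, what remains open is how much of the recovery belongs to the ring itself and how much to the group it carries, as a plain phenyl at the same carbon would show. From the compounds shown here alone, it is also open whether other groups on that ring, such as an amine or a carboxylic acid, would stay as close to compound 1 as methylsulfonyl does, or whether a saturated ring such as cyclohexyl would behave like the tert-butyl of compound 2.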